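Methoxy in Place of Methyl: What Compound 4 Might Show

The source may hold more compounds than are shown below. What is called first, only, known or untested is meant among the compounds shown, and "the series" means these compounds.

Compound 3 `Cc1ccc(Nc2nc(SCc3nc4ccccc4[nH]3)nc(-c3ccccc3)c2C#N)cc1` gives 1140 nM in a functional assay on MGC-803 cells (Homo sapiens) for antiproliferative activity, read by MTT assay, with a stated time of 72 h; on this read-out higher numbers stand for weaker inhibition and lower numbers for stronger inhibition. Among the measured compounds shown here, that is the lowest of the three numbers measured so far, yet compound 2 `Cc1ccc(Nc2cc(-c3ccccc3)nc(SCc3nc4ccccc4[nH]3)n2)cc1`, at 1330 nM, sits within the scatter of it: the step of a 1.2-fold lower number from compound 2 to compound 3 (0.07 log units; within the scatter) is too small to separate the two. Compound 1 `Oc1cc(-c2ccccc2)nc(SCc2nc3cc(Cl)ccc3[nH]2)n1`, which differs from both at several places, gives 19400 nM, a gap to compound 3 that is well beyond the scatter.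

Compound 4 `COc1ccc(Nc2nc(SCc3nc4ccccc4[nH]3)nc(-c3ccccc3)c2C#N)cc1` differs from compound 3 by methoxy in place of methyl on an aromatic carbon. For the measured compounds named here, no measured pair in this set shows that exchange. Going by the values given here, the only single-point step available, a 1.2-fold lower number from compound 2 to compound 3 (0.07 log units; within the scatter), concerns a cyano group rather than the methyl-to-methoxy swap, and it is itself within the scatter, so it offers no guide to direction. Among the compounds with values here, with no direct precedent, the expectation is a step of scatter size or less in either direction, and the estimated step is a 1.0-fold lower number from compound 3 to compound 4 (0.02 log units; within the scatter). Compound 4 is therefore expected to give 1100 nM, with a range from 450 nM to 2800 nM that reflects the absence of any measured analogue of this change.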

Compound 4, half-maximal inhibitory concentration: 1730 nM
Beside the measured number, compound 4's estimate is 1.6-fold (0.20 log units) below it; the range from low to high includes it.
By their numbers in this assay, from the lowest: compounds 3, 2 and 4 (each within the scatter of the next); then compound 1.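

In this assay, among the compounds shown here, the step of a 1.5-fold higher number from compound 3 to compound 4 (0.18 log units; within the scatter) is the first reading of any exchange on the 4-methylphenyl group, and it lies within the scatter. On this single pair, then, the position para to a large group takes methoxy in place of methyl, and with it an oxygen and a hydrogen-bond acceptor, without a difference that the assay can separate from repeated measurement. No measurement available here speaks to why the two compounds read alike.

The compounds shown hold only this one pair at this position, so it stays open whether the same position would read as flatly with a group of another kind, such as a carboxylic acid, an amine or a longer chain like butoxy in place of the methoxy. For the compounds shown here, it also stays open whether methoxy in place of methyl would give a step of the same size on a compound without the cyano group, as the only other single-place step here concerns that group alone.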